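One Ring Swap on a Sulfonyl-Linked Side Chain

The source may hold more compounds than are shown below. What is called first, only, known or untested is meant among the compounds shown, and "the series" means these compounds.

Compound 1 `O=S(=O)(CC1=NCCO1)c1c(-c2ccccc2)nn(-c2ccccc2)c1-c1ccccc1`: 63.5%
Compound 2 `O=S(=O)(CC1=NCCO1)C1=NNCC1c1ccccc1`: "not active" (no number reported)

In a functional assay, read by Griess assay, with a stated time of 150 min, tested at 100 ug/mL (on this read-out lower numbers stand for a weaker effect and higher numbers for a stronger effect at the one concentration tested), compound 1 gives 63.5%. Going by the values given here, it is the only compound with a number, because compound 2 is recorded in this assay only as "not active" (no number reported), without a figure. Among the compounds with values here, no step between measured compounds that differ in a single place is available. Compound 3 `O=S(=O)(CC1=NCCS1)c1c(-c2ccccc2)nn(-c2ccccc2)c1-c1ccccc1` differs from compound 1 by a group of 5 heavy atoms (3 carbon, 1 nitrogen, 1 sulfur; one five-membered non-aromatic ring with 2 hetero atoms) in place of a group of 5 heavy atoms (3 carbon, 1 nitrogen, 1 oxygen; one five-membered non-aromatic ring with 2 hetero atoms), on a saturated chain carbon bound to a sulfonyl sulfur. A change of this kind is expected to shift the read-out only a little, likely not beyond the usual scatter. Compound 3 is therefore estimated at 60%, within a range from 40% to 80%. The expected step is a number 3.5 percentage points lower from compound 1 to compound 3 (within the scatter).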

Compound 3, a percentage reported as activity, at one concentration (the size of the read-out at that concentration, not a potency): "not active" (no number reported)
Nothing numeric was reported for compound 3, and the estimate cannot be compared.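

Going by these compounds alone, compound 3 carries no number in this assay, so no step from compound 1 to compound 3 can be read. As far as these compounds go, how far the sulfur-containing ring changes the read-out stays open, and no measured property bears on this result.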